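The compounds below may be only part of what the source reports. "The series", "measured", "known", "first", "only" and "open" are said of these compounds alone.

Measured so far:
- Compound 1 `O=C(O)CC/C=C\C[C@@H]1CO[C@H](c2ccc(OCCn3ccnc3)c(C(=O)O)c2)O[C@@H]1c1ccccc1O`: 1260 nM
- Compound 2 `O=C(O)CC/C=C\C[C@@H]1CO[C@H](c2cncc(/C(=C/CCCCC(=O)O)c3ccccc3)c2)O[C@@H]1c1ccccc1O`: 39.8 nM

In a functional assay for antagonist activity, with Homo sapiens as the target (a higher number here means weaker binding, a lower number tighter binding), compound 2 gives 39.8 nM, the lower of the two numbers, and compound 1 gives 1260 nM, a gap well beyond the usual scatter. The next compound to be tested is compound 3 `O=C(O)CC/C=C\C[C@@H]1CO[C@H](c2cncc(/C(=C\CCCCC(=O)O)c3ccccc3)c2)O[C@@H]1c1ccccc1O`, a close relative of compound 2. The change between them is small: the two compounds have the same atoms and bonds and differ only in configuration as drawn: 1 of 5 stereo elements differ; a double bond is drawn E in compound 2 and Z in compound 3. Among the compounds with values here, no measured pair in this set shows what such a change does in this assay, so any expectation here is loose. A modest shift towards a higher number, meaning weaker binding, is expected, slightly beyond the scatter. The expected step is a 3.0-fold higher number from compound 2 to compound 3 (0.48 log units; beyond the scatter). The estimate for compound 3 is 120 nM, with a range of 30 nM to 500 nM.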

Compound 3, dissociation constant: 25.1 nM
Compound 3: the middle estimate sits 4.8-fold (0.68 log units) above what was measured; the whole stated range lies above it.
By their numbers in this assay, from the lowest: compounds 3 and 2 (each within the scatter of the next); then compound 1.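

Within the data shown here, compounds 2 and 3 form the first pair here that can be read as a single change, and the comparison is clean: the fact that compounds 2 and 3 differ only in the configuration as drawn. In this assay the step is a 1.6-fold lower number from compound 2 to compound 3 (0.20 log units; within the scatter), so swapping the double bond between E and Z leaves the two compounds indistinguishable. For this pair, then, the geometry of the double bond carrying the phenyl ring and the acid-bearing chain has no effect that this assay can resolve, something compound 1, which differs from both in more than one place, could not show.

The compounds shown leave open whether this indifference extends to a saturated chain in place of that double bond. They also leave open what a tetrazole in place of the carboxylic acid at the end of that chain would do.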